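Three weak inhibitors and a trimethoxyphenyl variant awaiting measurement

The source may hold more compounds than are shown below. What is called first, only, known or untested is meant among the compounds shown, and "the series" means these compounds.

Compound 1 `CN(Cc1ccc(-c2ccccc2)cc1)Cc1cn(C)c2ccc(CNc3ccc(F)cc3)cc12`: 84300 nM
Compound 2 `CN1CCN(Cc2cn(C)c3ccc(C(=O)Nc4ccc(F)cc4)cc23)CC1`: 89200 nM
Compound 3 `CN(Cc1ccc(-c2ccccc2)cc1)Cc1cn(C)c2ccc(C(=O)Nc3ccc(F)cc3)cc12`: > 100000 nM

In a functional assay on PC-3 cells (Homo sapiens) for antiproliferative activity, read by MTT assay, with a stated time of 72 h (on this read-out higher numbers stand for weaker inhibition and lower numbers for stronger inhibition), compound 1 gives 84300 nM. In this assay compound 2 gives 89200 nM. For compound 3 the read-out of this assay is only a limit, > 100000 nM, as recorded in the limit of > 100000 nM in this assay, at which 1 of the 3 values shown sits. Going by the values given here, compound 3 thus stands at the edge of what the assay reports, and the only step recorded for it, an at least 1.1-fold higher number from compound 1 to compound 3 (0.07 log units; that floor lies within the scatter), is itself bounded by that limit.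

Compound 4 `COc1cc(CN(C)Cc2cn(C)c3ccc(C(=O)Nc4ccc(F)cc4)cc23)cc(OC)c1OC` differs from compound 3 by 3,4,5-trimethoxyphenyl in place of 4-phenylphenyl on a saturated chain carbon bound to an amine nitrogen. Among the compounds with values here, none of the measured steps touches this position: the step from compound 1 to compound 3 concerns the amide, and compound 2 differs from compound 3 at the amine in another way, so its value can only be set beside the limit of compound 3. Within the data shown here, with no step bearing on the change, compound 4 is expected to remain near the limit, with an estimated step of an at least 1.1-fold lower number from compound 3 to compound 4 (0.04 log units; that floor lies within the scatter) in this assay. The estimate for compound 4 is 90000 nM, within 30000 nM to 270000 nM.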

Compound 4, half-maximal inhibitory concentration: 6450 nM
Compound 4: middle estimate off by 14-fold (1.14 log units), on the high side, and the stated range ends above it.
By their numbers in this assay, from the lowest: compound 4; then compounds 1 and 2 (each within the scatter of the next). At a limit, above all of these: compound 3.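

Going by these compounds alone, replacing 4-phenylphenyl with 3,4,5-trimethoxyphenyl on a saturated chain carbon bound to an amine nitrogen gives, in this assay, an at least 15-fold lower number from compound 3 to compound 4 (1.19 log units; beyond the scatter), so this position, which no earlier step touched, does bear on the read-out. The two groups hold the same number of heavy atoms, but the entering group has one six-membered aromatic ring where the leaving group has two, and 3 hydrogen-bond acceptors where the leaving group has 0, and the compounds shown do not separate these differences. The value of compound 3 is a limit, so that step gives only a floor: the limit of > 100000 nM in this assay, at which 1 of the 4 values shown sits.

On these data alone, it remains open whether the methoxy groups or the loss of the second ring accounts for the change, and what a plain phenyl or a hydroxyl-bearing phenyl would give at this position. Also open, as far as these compounds go, is how ((4-fluorophenyl)amino)methyl would fare in place of the (4-fluorophenyl)carbamoyl of compound 4.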